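Acid dissociation of a shared core with varied substituents

The compounds below may be only part of what the source reports. "The series", "measured", "known", "first", "only" and "open" are said of these compounds alone.

Compound 1 `c1ccc(-c2ccc3c(NCCCNCc4ccco4)ccnc3c2)cc1`: 9.47
Compound 2 `COc1cccc(CNCCCNc2ccnc3cc(-c4ccccc4)ccc23)c1O`: 9.47
Compound 3 `COc1ccc(F)cc1CNCCCNc1ccnc2cc(-c3ccccc3)ccc12`: 9.47

In a physicochemical assay for acid dissociation, compound 2 stands level with compounds 1 and 3 at the digits shown. The steps of no change at the digits printed from compound 1 to compound 2 (within the scatter), no change at the digits printed from compound 1 to compound 3 (within the scatter) and no change at the digits printed from compound 2 to compound 3 (within the scatter) all exchange the group on the saturated chain carbon bound to the amine nitrogen and leave the read-out unmoved within the scatter.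

Compound 4 `COc1cccc(CNCCCNc2ccnc3cc(CC4CCCCC4)ccc23)c1O` differs from compound 2 by cyclohexylmethyl in place of phenyl on an aromatic carbon. Going by the values given here, no measured step changes that place, so the only guidance is that the three varied compounds all sit at one value. Compound 4 is therefore expected to show no step beyond the scatter, a number 0.03 log units higher from compound 2 to compound 4 (within the scatter). The estimate for compound 4 is 9.5, between 9.2 and 9.8.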

Compound 4, acid dissociation constant: 9.47
The estimate for compound 4 lay 0.03 log units above the measured number, and the stated range covers the measured number.
By their numbers in this assay, from the lowest: compounds 1, 2, 3 and 4 (each within the scatter of the next).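

In this assay, cyclohexylmethyl in place of phenyl on an aromatic carbon of the shared core gives no change at the digits printed from compound 2 to compound 4 (within the scatter). Earlier steps only exchanged the group on the saturated chain carbon, so this shows that the read-out also stays within the scatter when the core substituent changes, here from an aromatic ring of carbon only to a non-aromatic one. Nothing at hand explains this flat result. On these data alone, it remains open whether an amine or a carboxylic acid at this aromatic carbon would move the number.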